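Pyrazinyl in place of tert-butyl on the amide nitrogen

The source may report more compounds than this note shows. Statements on the series, on what has been measured and on what is new or still open speak of the compounds shown alone.

Two amides of the shared core have been measured in an assay on HEK293 cells for agonist activity at transient receptor potential cation channel subfamily M member 8 (Homo sapiens), read by fluorescence and calcium flux, with a stated time of 15 min; a lower number here means that less compound is needed, a higher number that more compound is needed for the effect. Compound 1 `CCN(Cc1ccsc1)C(=O)COc1ccc(C)cc1` gives 88 nM. Compound 2 `Cc1ccc(OCC(=O)N(Cc2cccs2)C(C)(C)C)cc1` gives 11000 nM, the higher of the two numbers, and its gap to compound 1 lies beyond the usual scatter of this assay. Compound 3 `Cc1ccc(OCC(=O)N(Cc2cccs2)c2cnccn2)cc1` is the next member and has not been measured; it differs from compound 2 at the amide nitrogen: pyrazin-2-yl in place of tert-butyl on an amide-type nitrogen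

Within the data shown here, no measured pair of the series reports this change, so its direction rests on the two numbers alone. Since compound 2 carries the highest number of the pair, a modest downward step from compound 2 to compound 3 is expected, of size a 3.7-fold lower number from compound 2 to compound 3 (0.56 log units; beyond the scatter), though a result within the scatter of compound 2 would not surprise. Compound 3 is estimated at 3000 nM in this assay, within a range from 500 nM to 20000 nM.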

Compound 3, half-maximal effective concentration: 1240 nM
Estimate against measurement, compound 3: 2.4-fold (0.38 log units) above; the range from low to high includes it.
By their numbers in this assay, from the lowest: compound 1; then compound 3; then compound 2.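

In this assay, pyrazin-2-yl in place of tert-butyl on the amide-type nitrogen gives an 8.9-fold lower number from compound 2 to compound 3 (0.95 log units; beyond the scatter) and so shows that this position responds to the group it carries, while its other neighbours, the carbonyl carbon and the saturated chain carbon, stay the same. The change replaces a group with no ring and no hydrogen-bond acceptors by a six-membered aromatic ring with 2 hetero atoms and 2 hydrogen-bond acceptors, so this single step cannot separate the contribution of the ring from that of its nitrogens. No measurement at hand explains the step.

As far as these compounds go, whether the ring itself or its nitrogens carry the step remains open, and phenyl on this nitrogen would test that directly. Pyridin-2-yl would further show whether one ring nitrogen gives the same result as two.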